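A few compounds are considered here, and "the series" means these few. Any claim that something is new, unique, unknown or untested is made for them only; others in the source may bear on it.

Measured in an ADME assay on HepG2 2.2.15 cells (Homo sapiens) for cytotoxicity; on this read-out higher numbers stand for lower toxicity in this test and lower numbers for higher toxicity in this test:
- compound 1 `CCCCCCCC(=O)OCCc1c(-c2ccccc2Cl)c2cc(Cl)ccc2[nH]c1=O`: 78000 nM
- compound 2 `O=C(OCCc1c(-c2ccccc2Cl)c2cc(Cl)ccc2[nH]c1=O)C1CCCC1`: 46000 nM

Compound 2 stands within the scatter of compound 1. For the measured compounds named here, the only measured step, a 1.7-fold lower number from compound 1 to compound 2 (0.23 log units; within the scatter), changes the same place as the next one and is within the scatter. Next is compound 3 `O=C(OCCc1c(-c2ccccc2Cl)c2cc(Cl)ccc2[nH]c1=O)c1cccnc1`: pyridin-3-yl in place of cyclopentyl on a carbonyl carbon. Going by the values given here, no measured compound carries an aromatic ring at this place, so the basis is thin, and no shift beyond the scatter is expected in this assay. The expected change is a 1.2-fold lower number from compound 2 to compound 3 (0.06 log units; within the scatter). Compound 3 is estimated at 40000 nM, with an expected range of 15000 nM to 100000 nM.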

Compound 3, half-maximal cytotoxic concentration: 170000 nM
For compound 3 the middle estimate is 4.3-fold (0.63 log units) below the measured one; the whole stated range lies below it.
By their numbers in this assay, from the lowest: compounds 2 and 1 (each within the scatter of the next); then compound 3.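

Pyridin-3-yl on the carbonyl carbon gives a 3.7-fold higher number from compound 2 to compound 3 (0.57 log units; beyond the scatter) and a 2.2-fold higher number from compound 1 to compound 3 (0.34 log units; beyond the scatter) in this assay as measured here. This place can therefore move the read-out beyond the scatter, which the heptyl and cyclopentyl pair did not show. Nothing at hand accounts for the shift. Still open, from the compounds shown here alone, is whether phenyl, which has no ring nitrogen, gives the same higher number as pyridin-3-yl. Also open, going by these compounds, is how pyridin-4-yl or an amine-bearing chain on this carbonyl carbon would read.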